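This account rests on a few compounds, and the source may have more. Where it says the series, first, only, none or still open, it means among the compounds named here.

In an ADME assay on CCRF-CEM cells (Homo sapiens) for cytotoxicity, read by cell counting (on this read-out lower numbers stand for higher toxicity in this test and higher numbers for lower toxicity in this test), compound 2 `Cc1cc(C)cc(S(=O)(=O)c2c(C(=O)NCN3CCCC3)[nH]c3ccc(Cl)cc23)c1` gives 11000 nM. This lies within the usual scatter of compound 1 `Cc1cc(C)cc(S(=O)(=O)c2c(C(=O)NCN3CCCC3)[nH]c3ccc(Br)cc23)c1` at 9600 nM and of compound 3 `Cc1cc(C)cc(S(=O)(=O)c2c(C(=O)NCN3CCCC3)[nH]c3ccc(Cl)c(F)c23)c1` at 9300 nM. Compound 4 `Cc1cc(C)cc(S(=O)(=O)c2c(C(=O)NCc3ccccc3)[nH]c3ccc(Cl)cc23)c1` alters the side chain on the amide: phenyl in place of pyrrolidin-1-yl on a saturated chain carbon bound to an amide-type nitrogen. In words, this is phenyl in place of pyrrolidin-1-yl on a saturated chain carbon bound to an amide-type nitrogen. The two measured steps, a 1.1-fold higher number from compound 1 to compound 2 (0.06 log units; within the scatter) and a 1.2-fold lower number from compound 2 to compound 3 (0.07 log units; within the scatter), are both within the scatter, but they concern the bromo, chloro and fluoro groups and leave this side chain untouched. They therefore offer only weak guidance and no direction, so no step beyond the scatter is expected in this assay, and the estimate is a 1.1-fold lower number from compound 2 to compound 4 (0.04 log units; within the scatter). Compound 4 is expected at 10000 nM, with an estimated range from 3500 nM to 30000 nM.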

Compound 4, half-maximal cytotoxic concentration: 244000 nM
Beside the measured number, compound 4's estimate is 24-fold (1.39 log units) below it; the whole stated range lies below it.
By their numbers in this assay, from the lowest: compounds 3, 1 and 2 (each within the scatter of the next); then compound 4.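

In this assay the side chain on the amide matters far more than the bromo, chloro and fluoro changes did, which all stayed within the scatter. Phenyl in place of pyrrolidin-1-yl on this saturated chain carbon gives a 22-fold higher number from compound 2 to compound 4 (1.35 log units; beyond the scatter) and so a large shift towards lower toxicity in this test. Nothing shown here explains this shift. Going by these compounds, it remains open whether losing pyrrolidin-1-yl or gaining phenyl matters more, and a dimethylamino group or a longer chain carrying the phenyl could help separate the two. Whether bromo or fluoro changes stay as flat alongside the benzyl group is also unknown.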